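Benzyloxy to phenoxy from compound 1 to compound 3

The source may hold more compounds than are shown below. What is called first, only, known or untested is meant among the compounds shown, and "the series" means these compounds.

- compound 1 `NS(=O)(=O)c1ccc(N2N=C(c3ccc(OCc4ccccc4)cc3)CC2c2ccccc2)cc1` gives > 100000 nM as a limit
- compound 2 `NS(=O)(=O)c1ccc(N2N=C(c3ccc(OCc4ccccc4)cc3)CC2c2ccc(F)cc2)cc1` gives > 100000 nM as a limit

Both compounds were read in an ADME assay on MT4 cells (Homo sapiens) for cytotoxicity, read by MTT assay, with a stated time of 96 h (a lower number here means that less compound is tolerated, a higher number that more compound is tolerated), and neither returned a number. Compound 1 therefore stands only at a limit.

Compound 3 `NS(=O)(=O)c1ccc(N2N=C(c3ccc(Oc4ccccc4)cc3)CC2c2ccccc2)cc1` differs from compound 1 by phenyl in place of benzyl on an oxygen on an aromatic ring and so carries phenyl in place of benzyl on an oxygen on an aromatic ring. For the measured compounds named here, the one measured step is a step that the two limits leave unreadable from compound 1 to compound 2 and it concerns a different change, fluoro in place of hydrogen on an aromatic carbon, so it offers no size to carry over. All that bears on the new change is the limit of > 100000 nM in this assay, at which 2 of the 2 values shown sit, and it sets no direction. No step beyond the scatter is therefore expected in this assay for this change. The estimated step is a number no higher from compound 1 to compound 3 (the limit leaves the size open) and it is expected to stay unreadably small. Compound 3 is estimated at 100000 nM with an expected range from 50000 nM to 200000 nM and may well report only a limit again.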

Compound 3, half-maximal cytotoxic concentration: 42000 nM
Compound 3: the middle estimate sits 2.4-fold (0.38 log units) above what was measured, and the stated range ends above it.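

Phenyl in place of benzyl on the oxygen is the first change in this series that gives a readable step: in this assay it gives an at least 2.3-fold lower number from compound 1 to compound 3 (0.37 log units; beyond the scatter). For the compounds shown here, this place on the aryl ether can therefore shift the read-out, whereas the only earlier step, fluoro in place of hydrogen on an aromatic carbon, cannot be read because both of its ends are limits. Compound 3 is the only compound shown with a number, and the other two remain at a limit: the limit of > 100000 nM in this assay, at which 2 of the 3 values shown sit.

From the compounds shown here alone, the direction rests on this single pair, so it remains open whether the same change would lower the number in the fluoro compound 2. The compounds shown also leave open how a methyl group or a longer chain such as phenethyl on that oxygen would read.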